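Changing one sulfonyl group: compound 3 to compound 4

This account rests on a few compounds, and the source may have more. Where it says the series, first, only, none or still open, it means among the compounds named here.

Compound 1 `Cc1ccc(-c2nn(-c3ccccc3)cc2-c2nc3ccccc3n2S(=O)(=O)c2ccc(Cl)cc2)cc1` gives 5520 nM
Compound 2 `O=S(=O)(c1ccccc1)n1c(-c2cn(-c3ccccc3)nc2-c2ccc(C(F)(F)F)cc2)nc2ccccc21` gives 590 nM
Compound 3 `Cc1ccc(C)c(S(=O)(=O)n2c(-c3cn(-c4ccccc4)nc3-c3ccc(C(F)(F)F)cc3)nc3ccccc32)c1` gives 330 nM

In a functional assay on HepG2 cells (Homo sapiens) for antiproliferative activity, read by MTT assay, with a stated time of 24 h (on this read-out higher numbers stand for weaker inhibition and lower numbers for stronger inhibition), compound 3 gives 330 nM and sits together with compound 2 at the low end of the three numbers, while compound 1 lies clearly higher. The next compound to be measured, compound 4 `O=S(=O)(c1ccc(Cl)cc1)n1c(-c2cn(-c3ccccc3)nc2-c2ccc(C(F)(F)F)cc2)nc2ccccc21`, differs from compound 3 at one place only: 4-chlorophenyl in place of 2,5-dimethylphenyl on a sulfonyl sulfur. Put simply, it carries 4-chlorophenyl in place of 2,5-dimethylphenyl on a sulfonyl sulfur.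

Among the measured compounds shown here, only one measured step changes this group and leaves the rest alone: a 1.8-fold lower number from compound 2 to compound 3 (0.25 log units; within the scatter), where 2,5-dimethylphenyl took the place of phenyl. Here, then, changing the group moved the number no further than repeat measurements would. Compound 1 also holds 4-chlorophenyl on that sulfur and gives 5520 nM, but it differs from compound 4 elsewhere too, so that value cannot be pinned on this group alone.

The evidence is thin, and no clear shift in either direction is expected. The expected change is a 1.4-fold higher number from compound 3 to compound 4 (0.13 log units; within the scatter), an estimate that stays inside the usual scatter. In this assay the estimate for compound 4 is 450 nM, with an expected range from 150 nM to 1500 nM.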

Compound 4, half-maximal inhibitory concentration: 3930 nM
For compound 4 the middle estimate is 8.7-fold (0.94 log units) below the measured one, and the stated range ends below it.
By their numbers in this assay, from the lowest: compounds 3 and 2 (each within the scatter of the next); then compounds 4 and 1 (each within the scatter of the next).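

In this assay, among the compounds shown here, the group on the sulfonyl sulfur proves able to move the number well beyond the scatter: replacing 2,5-dimethylphenyl with 4-chlorophenyl gives a 12-fold higher number from compound 3 to compound 4 (1.08 log units; beyond the scatter), whereas the only earlier step at this place, from phenyl to 2,5-dimethylphenyl, stayed within it. The comparison with the plain phenyl compound isolates a single atom, since chloro in place of hydrogen on an aromatic carbon gives a 6.7-fold higher number from compound 2 to compound 4 (0.82 log units; beyond the scatter), a modest step but a real one. With 4-chlorophenyl on the sulfur, trifluoromethyl in place of methyl on an aromatic carbon gives a 1.4-fold lower number from compound 1 to compound 4 (0.15 log units; within the scatter) and stays within the scatter, so in this pair that swap shows no measurable effect and the two compounds sit together at the high end.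

No measured property is available to explain these steps. From the compounds shown here alone, whether the rise belongs to chloro in particular stays open, as does the response of this sulfonyl position to other groups on the phenyl ring, such as a methoxy group or an amine.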